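Lengthening the amine arm from compound 3 to compound 4

The compounds below may be only part of what the source reports. "The series", "measured", "known", "first", "only" and "open" are said of these compounds alone.

Compound 1 `CCn1c(N)c(-c2nc3ccccc3[nH]2)c2nc(C#N)c(C#N)nc21`, compound 2 `CN(C)CCn1c(N)c(-c2nc3ccccc3[nH]2)c2nc(C#N)c(C#N)nc21` and compound 3 `N#Cc1nc2c(-c3nc4ccccc4[nH]3)c(N)n(CCN3CCCC3)c2nc1C#N` share one core and differ only in the chain on the aromatic nitrogen. In an ADME assay on HEK293 cells (Homo sapiens) for cytotoxicity, read by MTT assay, with a stated time of 48 h (a lower number here means a stronger inhibitor, a higher number a weaker inhibitor), compound 1 reaches only the assay's limit, > 50000 nM. Compound 2 gives 9730 nM. Compound 3 gives 18300 nM, the higher of the two numbers, with compound 2 nearest a 1.9-fold higher number from compound 2 to compound 3 (0.27 log units; within the scatter). Compound 4 `CN(C)CCCn1c(N)c(-c2nc3ccccc3[nH]2)c2nc(C#N)c(C#N)nc21` differs from compound 3 by (dimethylamino)methyl in place of pyrrolidin-1-yl on a saturated chain carbon, two bonds along the chain from an aromatic nitrogen. Among the compounds with values here, the steps that bear on this are an at least 5.1-fold lower number from compound 1 to compound 2 (0.71 log units; beyond the scatter) and an at least 2.7-fold lower number from compound 1 to compound 3 (0.43 log units; beyond the scatter), both starting from a limit, and the small gap a 1.9-fold higher number from compound 2 to compound 3 (0.27 log units; within the scatter). Because a 1.9-fold higher number from compound 2 to compound 3 (0.27 log units; within the scatter) lies within the scatter, no step beyond the scatter is expected for compound 4. Compound 4 is estimated at 13000 nM, between 5000 nM and 32000 nM. For compound 4 this expected step reads a 1.4-fold lower number from compound 3 to compound 4 (0.15 log units; within the scatter).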

Compound 4, half-maximal inhibitory concentration: 8360 nM
Compound 4: the middle estimate sits 1.6-fold (0.19 log units) above what was measured; measured number inside the range.
By their numbers in this assay, from the lowest: compounds 4, 2 and 3 (each within the scatter of the next, the first and the last beyond it). At a limit, above all of these: compound 1.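

In this assay, the 2-(dimethylamino)ethyl and 3-(dimethylamino)propyl chains cannot be told apart, with a 1.2-fold lower number from compound 2 to compound 4 (0.07 log units; within the scatter). Against the 2-(pyrrolidin-1-yl)ethyl chain, the 3-(dimethylamino)propyl chain gives a 2.2-fold lower number from compound 3 to compound 4 (0.34 log units; beyond the scatter), the first step beyond the scatter among the compounds carrying an amine on the chain. The remaining step, an at least 5.9-fold lower number from compound 1 to compound 4 (0.77 log units; beyond the scatter), starts from a limit and so gives only a bound: the limit of > 50000 nM in this assay, at which 1 of the 4 values shown sits.

The compounds shown leave open how a 3-(pyrrolidin-1-yl)propyl chain, a morpholin-4-yl group or a longer chain would read here. Going by these compounds, it therefore remains open whether chain length or the kind of amine matters more.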